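The source may hold more compounds than are shown below. What is called first, only, known or untested is meant among the compounds shown, and "the series" means these compounds.

Compounds measured in an assay on isolated protein for inhibition of Fatty-acid amide hydrolase 1 (Homo sapiens); on this read-out higher numbers stand for weaker inhibition and lower numbers for stronger inhibition:
- compound 1, `CCCCCCCC/C=C\CCCCCCC(=O)c1ccccn1`: > 100000 nM
- compound 2, `CCCCCCCC/C=C\CCCCCCC(=O)c1nnn(C)n1`: 65 nM
- compound 3, `CCCCCCCC/C=C\CCCCCCC(=O)c1ccncn1`: 110 nM

The value for compound 1 is a limit of this assay, not a number (the limit of > 100000 nM in this assay, at which 1 of the 3 values shown sits). Compound 3 stands as the higher of the two numbers, with compound 2 nearest; the gap a 1.7-fold higher number from compound 2 to compound 3 (0.23 log units; within the scatter) lies within the scatter, so the two are not told apart. Both heterocycles, however, sit far from the limit of compound 1: an at least 1500-fold lower number from compound 1 to compound 2 (3.18 log units; beyond the scatter) and an at least 900-fold lower number from compound 1 to compound 3 (2.95 log units; beyond the scatter) are large.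

Compound 4, `CCCCCCCC/C=C\CCCCCCC(=O)c1nc2ncccc2o1`, is not yet measured. The change from compound 3 is a group of 9 heavy atoms (6 carbon, 2 nitrogen, 1 oxygen; one five-membered aromatic ring with 2 hetero atoms, one six-membered aromatic ring with 1 hetero atom) in place of a group of 6 heavy atoms (4 carbon, 2 nitrogen; one six-membered aromatic ring with 2 hetero atoms), on a carbonyl carbon. Among the measured compounds shown here, no measured step replaces one heterocycle by a bicyclic one, so the size of the step rests on the two steps from compound 1, which show that the heterocycle on the carbonyl carbon governs this read-out, and on the near-identity of compound 2 and compound 3, which shows that exchanging one nitrogen-containing aromatic ring for another need not move the number much.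

Compound 4 is therefore expected to remain well clear of the limit and to give a number somewhat lower than compound 3, estimated at 15 nM with a range of 2 nM to 120 nM; this expectation corresponds to the step of a 7.3-fold lower number from compound 3 to compound 4 (0.87 log units; beyond the scatter).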

Compound 4, inhibition constant: 2.3 nM
The estimate for compound 4 lay 6.5-fold (0.81 log units) above the measured number; measured number inside the range.
By their numbers in this assay, from the lowest: compound 4; then compounds 2 and 3 (each within the scatter of the next). At a limit, above all of these: compound 1.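

In this assay compounds 2 and 3 could not be told apart despite their different single-ring heterocycles, whereas the two-ring group on the carbonyl carbon of compound 4 does separate from both, with a 48-fold lower number from compound 3 to compound 4 (1.68 log units; beyond the scatter) and a 28-fold lower number from compound 2 to compound 4 (1.45 log units; beyond the scatter) both large. The value of compound 1 is a limit of the assay, not a number: (the limit of > 100000 nM in this assay, at which 1 of the 4 values shown sits). With the chain unchanged, exchange of the heterocycle alone gives an at least 43000-fold lower number from compound 1 to compound 4 (4.63 log units; beyond the scatter) and leaves compound 4 as the strongest inhibitor of the four shown.

The compounds shown do not separate the contribution of the ring oxygen from that of the added ring or of the nitrogen in the six-membered ring, and a benzoxazol-2-yl group, which has no nitrogen in its six-membered ring, would bear on this. Also open, going by these compounds, is whether the two-ring group holds its advantage on a different chain, such as a shorter saturated chain or one carrying a carboxylic acid.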